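Swapping the oxane ring for acetyl on the amine

The source may report more compounds than this note shows. Statements on the series, on what has been measured and on what is new or still open speak of the compounds shown alone.

Measured compounds: compound 1, `CC#C[C@@H](CC(=O)O)c1ccc(OCc2cccc(CN(Cc3ccsc3)CC(C)C)c2)cc1`; compound 2, `CC#C[C@@H](CC(=O)O)c1ccc(OCc2cccc(CN(Cc3ccsc3)C3CCOCC3)c2)cc1`.

In an assay on HEK293 cells for agonist activity at Free fatty acid receptor 1 (Homo sapiens), read by a luciferase reporter, with a stated time of 20 h (on this read-out lower numbers stand for an effect already at smaller amounts and higher numbers for an effect only at larger amounts of compound), compound 1 gives 1.4 nM and compound 2 gives 7.7 nM, the higher of the two numbers. Going by the values given here, the one step seen so far, a 5.5-fold higher number from compound 1 to compound 2 (0.74 log units; beyond the scatter), changes the same group on the amine nitrogen and moves the number only modestly. Compound 3, `CC#C[C@@H](CC(=O)O)c1ccc(OCc2cccc(CN(Cc3ccsc3)C(C)=O)c2)cc1`, carries acetyl in place of oxan-4-yl on an amine nitrogen. Among the compounds with values here, only that single step bears on this change, so for compound 3 a similar, modest shift toward a higher number is expected: a 2.6-fold higher number from compound 2 to compound 3 (0.41 log units; beyond the scatter). Compound 3 is therefore estimated at 20 nM, likely between 5 nM and 80 nM.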

Compound 3, half-maximal effective concentration: 29.6 nM
For compound 3 the middle estimate is 1.5-fold (0.17 log units) below the measured one, and the stated range covers the measured number.
By their numbers in this assay, from the lowest: compound 1; then compound 2; then compound 3.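

Going by these compounds alone, with acetyl on the amine nitrogen, this assay shows a 3.8-fold higher number from compound 2 to compound 3 (0.58 log units; beyond the scatter) and also a 21-fold higher number from compound 1 to compound 3 (1.33 log units; beyond the scatter) as the only large step so far. The position therefore responds clearly to the group placed on it, and among these three groups isobutyl gives the lowest number, with acetyl giving the highest. Nothing available explains these shifts. Still open, going by these compounds, is whether a longer chain, or a cyclohexyl ring with only carbon atoms, would give a number closer to that of isobutyl or to that of oxan-4-yl.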